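This account rests on a few compounds, and the source may have more. Where it says the series, first, only, none or still open, it means among the compounds named here.

Among the compounds with values here, compound 1, `NS(=O)(=O)c1ccc(S(=O)(=O)CCCO)cc1`, has the lower of the two numbers measured so far: in a physicochemical assay for solubility, at pH 7.4 (on this read-out lower numbers stand for lower solubility and higher numbers for higher solubility), compound 1 gives 7200 ug/mL, while compound 2, `NS(=O)(=O)c1ccc(S(=O)(=O)CC(O)CO)cc1`, gives 14900 ug/mL. Within the data shown here, the one measured step, a 2.1-fold higher number from compound 1 to compound 2 (0.32 log units; beyond the scatter), concerns a change on the saturated chain. Compound 3, `NS(=O)(=O)c1ccc(S(=O)(=O)CCCO)c([N+](=O)[O-])c1`, differs from compound 1 elsewhere: nitro in place of hydrogen on an aromatic carbon. Among the measured compounds shown here, no measured step bears on a change at an aromatic carbon, so for compound 3 in this assay the expected step is a 1.2-fold lower number from compound 1 to compound 3 (0.08 log units; within the scatter), a shift not beyond the scatter. Compound 3 is therefore estimated at 6000 ug/mL, within a range from 2500 ug/mL to 14000 ug/mL.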

Compound 3, solubility: 800 ug/mL
Estimate against measurement, compound 3: 7.5-fold (0.88 log units) above; the whole stated range lies above it.
By their numbers in this assay, from the lowest: compound 3; then compound 1; then compound 2.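

Nitro in place of hydrogen on this aromatic carbon, ortho to a group of 7 heavy atoms and meta to a sulfamoyl group, gives a 9.0-fold lower number from compound 1 to compound 3 (0.95 log units; beyond the scatter) in this assay. This shows that a change on the ring can move the read-out beyond the scatter, and in the opposite direction to the hydroxy change on the saturated chain. No information bearing on the reason for this step is available. Still open, as far as these compounds go, is whether this step belongs to nitro itself or would also follow another group on this carbon, such as an amine or a chlorine atom.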